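Lipophilicity shift from pyridin-3-yl to phenoxymethyl in two cores

The compounds below may be only part of what the source reports. "The series", "measured", "known", "first", "only" and "open" are said of these compounds alone.

Compound 1 `OC[C@H]1O[C@H](n2cc(-c3cccnc3)nn2)[C@@H](O)[C@@H](O)[C@@H]1O` and compound 2 `OC[C@H]1O[C@H](n2cc(COc3ccccc3)nn2)[C@@H](O)[C@@H](O)[C@@H]1O` share one core. In a physicochemical assay for lipophilicity, read by LC-MS, using the shake flask method, in phosphate buffer, measured as octanol-water partition, with a stated time of 2 h, at pH 7.4 (on this read-out higher numbers stand for higher lipophilicity and lower numbers for lower lipophilicity), compound 1 gives -1.04, while compound 2 gives -0.18. The change between them, (phenoxymethyl in place of pyridin-3-yl on an aromatic carbon), gives a step of a number 0.86 log units higher from compound 1 to compound 2 (beyond the scatter).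

Compound 3 `OC[C@H]1O[C@H](Cn2cc(-c3cccnc3)nn2)[C@@H](O)[C@@H](O)[C@@H]1O` sits on a second core; how its core differs from that of compound 1 is not broken down here. In this assay compound 3 gives only a limit, < -1.5, as noted in the limit of < -1.5 in this assay, at which 1 of the 3 values shown sits.

Compound 4 `OC[C@H]1O[C@H](Cn2cc(COc3ccccc3)nn2)[C@@H](O)[C@@H](O)[C@@H]1O` carries the same change on the second core, (phenoxymethyl in place of pyridin-3-yl on an aromatic carbon). Since the change is the same, and the two place lines agree word for word, a step like that from compound 1 to compound 2 is expected, giving a number at least 0.60 log units higher from compound 3 to compound 4 (beyond the scatter) for compound 4, starting from a value that is only known as a limit. Compound 4 is therefore expected at -0.9, within -1.4 to -0.4.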

Compound 4, distribution coefficient: -0.83
Compound 4: middle estimate off by 0.07 log units, on the low side; the range from low to high includes it.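

In this assay, phenoxymethyl in place of pyridin-3-yl on an aromatic carbon gives a number at least 0.67 log units higher from compound 3 to compound 4 (beyond the scatter), in the same direction as a number 0.86 log units higher from compound 1 to compound 2 (beyond the scatter). The direction of the change therefore carries over between these two cores, on one pair of compounds per core. The size of the step on the second core stays unfixed and cannot be equated with that on the first, because the value for compound 3 is a limit and not a number: the limit of < -1.5 in this assay, at which 1 of the 4 values shown sits.

Open, as far as these compounds go, is whether the same direction holds for a basic amine or a carboxylic acid on that aromatic carbon. Also open, from the compounds shown here alone, is whether a longer chain between the oxygen and the aromatic ring of phenoxymethyl would follow it.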